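Swapping the Aryl Ring on a Nanomolar IDO1 Inhibitor

The source may report more compounds than this note shows. Statements on the series, on what has been measured and on what is new or still open speak of the compounds shown alone.

Compound 1 `NS(=O)(=O)CC(=O)NCCSc1nonc1/C(=N/O)Nc1cccc(Br)c1` gives the lowest number of the three measured compounds in an assay for inhibition of Indoleamine 2,3-dioxygenase 1 (Homo sapiens), read by fluorescence, with a stated time of 1 h (a lower number here means a stronger inhibitor, a higher number a weaker inhibitor), at 30 nM. Compound 2 `CS(=O)(=O)NCCSc1nonc1/C(=N/O)Nc1ccc(F)c(Br)c1` gives 270 nM, and compound 3 `CSc1nonc1/C(=N/O)Nc1ccc(F)c(Br)c1` gives 560 nM. For the measured compounds named here, the only step measured between two compounds that differ in a single place, a 2.1-fold higher number from compound 2 to compound 3 (0.32 log units; beyond the scatter), concerns the chain bound to sulfur, not the aryl ring. Compound 4 `N#Cc1cc(N/C(=N\O)c2nonc2SCCNC(=O)CS(N)(=O)=O)ccc1F` differs from compound 1 only at that ring: 3-cyano-4-fluorophenyl in place of 3-bromophenyl on an amine nitrogen. Going by the values given here, no measured step bears directly on this change; compound 1 and compound 2 differ both at the ring and on the chain. A small step, if any, toward a lower number is expected: a 1.5-fold lower number from compound 1 to compound 4 (0.18 log units; within the scatter). Compound 4 is therefore estimated at 20 nM, with a range from 7 nM to 60 nM.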

Compound 4, half-maximal inhibitory concentration: 150 nM
Compound 4: the middle estimate sits 7.5-fold (0.88 log units) below what was measured; measured number outside the range, above it.
By their numbers in this assay, from the lowest: compound 1; then compounds 4 and 2 (each within the scatter of the next); then compound 3.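

In this assay, 3-cyano-4-fluorophenyl in place of 3-bromophenyl on an amine nitrogen gives a 5.0-fold higher number from compound 1 to compound 4 (0.70 log units; beyond the scatter) with the chain on sulfur unchanged. For the compounds shown here, this shows that the aryl ring alone moves the number beyond the scatter, which the earlier compounds could not show, as they differ at both the ring and the chain. Nothing measured here accounts for this difference.

On these data alone, the nitrile and the fluorine enter together, so what each contributes remains open. Also open, as far as these compounds go, is how a 3-cyanophenyl or 3-chlorophenyl ring would compare at this position.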